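The source may report more compounds than this note shows. Statements on the series, on what has been measured and on what is new or still open speak of the compounds shown alone.

Compound 2 `CC(C)(C)c1ccc(/C=N/n2cnnc2)cc1` gives 6440 nM in an assay for inhibition of Alpha amylase (Homo sapiens), with a stated time of 10 min (on this read-out lower numbers stand for stronger inhibition and higher numbers for weaker inhibition), the highest of the two numbers seen so far; compound 1 `Oc1ccc(/C=N/n2cnnc2)cc1` gives 2990 nM in this assay. Compound 3 `Clc1ccc(/C=N/n2cnnc2)cc1` carries chloro in place of tert-butyl on an aromatic carbon. Among the compounds with values here, the one measured step, a 2.2-fold higher number from compound 1 to compound 2 (0.33 log units; beyond the scatter), is modest and bears only indirectly, since no measured pair swaps tert-butyl for chloro. With chloro counted at one heavy atom against four for tert-butyl, a small downward step is expected, a 1.4-fold lower number from compound 2 to compound 3 (0.16 log units; within the scatter), likely within or near the scatter. Compound 3 is therefore estimated at 4500 nM in this assay, within a range of 2000 nM to 10000 nM.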

Compound 3, half-maximal inhibitory concentration: 4360 nM
Estimate against measurement, compound 3: 1.0-fold (0.01 log units) above; measured number inside the range.
By their numbers in this assay, from the lowest: compounds 1, 3 and 2 (each within the scatter of the next, the first and the last beyond it).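

Two readings now place chloro at this position: a 1.5-fold lower number from compound 2 to compound 3 (0.17 log units; within the scatter) against tert-butyl and a 1.5-fold higher number from compound 1 to compound 3 (0.16 log units; within the scatter) against hydroxy. Chloro therefore cannot be separated from either group, and the hydroxy to tert-butyl pair remains the only step here beyond the scatter. As far as these compounds go, whether an amine, a carboxylic acid or a methoxy group on this aromatic carbon would leave this narrow band stays open, as does whether bromo or fluoro would read like chloro. No available evidence bears on why these three groups read so closely.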